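The source may hold more compounds than are shown below. What is called first, only, known or untested is meant among the compounds shown, and "the series" means these compounds.

Measured so far:
compound 1 `CCCCN(C(=O)c1ccc(C(F)(F)F)cc1)c1nnc(-c2ccc(S(=O)(=O)NCCC(=O)O)cc2)s1` — 99.6 uL/min
compound 2 `CCCCN(C(=O)c1ccc(C(F)(F)F)cc1)c1nnc(-c2cccc3[nH]ccc23)s1` — 43.2 uL/min

In an ADME assay on microsomes from liver (Rattus norvegicus) for metabolic stability, read by LC-MS, tested at 0.5 uM (a higher number here means faster removal of the compound, a lower number slower removal), compound 2 gives the lower of the two numbers; compound 1 stands higher, by a gap beyond the usual scatter. Compound 3 `CCCCN(C(=O)c1ccc(C(F)(F)F)cc1)c1nnc(-c2ccc(F)c3[nH]ccc23)s1` is not yet measured. It differs from compound 2 in one place: fluoro in place of hydrogen on an aromatic carbon. For the measured compounds named here, no measured pair here isolates this change, so nothing in the data sets its size. A small step is expected, a 1.1-fold lower number from compound 2 to compound 3 (0.03 log units; within the scatter), not clearly beyond the scatter in either direction. For compound 3 the value expected in this assay is 40 uL/min, within a range from 20 uL/min to 80 uL/min.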

Compound 3, intrinsic clearance in a liver preparation (reported as CLH), per the amount of preparation that the assay uses: 43 uL/min
Beside the measured number, compound 3's estimate is 1.1-fold (0.03 log units) below it; low and high end bracket the measured number.
By their numbers in this assay, from the lowest: compounds 3 and 2 (each within the scatter of the next); then compound 1.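

In this assay, for the compounds shown here, fluoro in place of hydrogen on an aromatic carbon, para to a large group and ortho to a fused ring, gives a 1.0-fold lower number from compound 2 to compound 3 (0.00 log units; within the scatter) as the first reading that isolates a single change. At this position, then, fluoro leaves the clearance reading within the scatter of hydrogen. Nothing at hand explains this outcome.

Going by these compounds, whether a larger group here, such as chloro, methoxy or nitrile, would behave the same remains open. So does whether fluoro at other aromatic carbons of the fused system would give a similar reading.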